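The source may hold more compounds than are shown below. What is called first, only, known or untested is meant among the compounds shown, and "the series" means these compounds.

Measured so far:
- compound 1 `O=C(O)c1cc(-c2cocn2)ccc1O`: 110 mg/kg
- compound 2 `O=C(O)c1ccc(-c2cscn2)cc1O`: 70 mg/kg

In a functional assay on the whole organism for inhibition, with Rattus norvegicus as the target, read by paw edema (on this read-out higher numbers stand for an effect only at larger amounts of compound and lower numbers for an effect already at smaller amounts), compound 1 gives 110 mg/kg and stands at the top of the two numbers shown, while compound 2 gives 70 mg/kg, a gap that lies within the usual scatter. Compound 3 `O=C(O)c1cc(-n2cccn2)ccc1O` differs from compound 1 by 1H-pyrazol-1-yl in place of 1,3-oxazol-4-yl on an aromatic carbon. Among the measured compounds shown here, no step between measured compounds is available to guide this change, so a step of no change at the digits printed from compound 1 to compound 3 (within the scatter) of no size beyond the scatter is expected. Compound 3 is therefore estimated at 110 mg/kg, with a range from 50 mg/kg to 250 mg/kg.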

Compound 3, dose for half-maximal effect: 200 mg/kg
The estimate for compound 3 lay 1.8-fold (0.26 log units) below the measured number; the range from low to high includes it.
By their numbers in this assay, from the lowest: compounds 2, 1 and 3 (each within the scatter of the next, the first and the last beyond it).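

In this assay, placing 1H-pyrazol-1-yl instead of 1,3-oxazol-4-yl on the aromatic carbon para to the hydroxy group and meta to the carboxy group gives a 1.8-fold higher number from compound 1 to compound 3 (0.26 log units; within the scatter). At this position, then, one five-membered aromatic ring with 2 hetero atoms can replace another without a step beyond the scatter. Nothing available explains the size of this step. Still open, going by these compounds, is whether a different kind of group here, such as an amine or a longer alkyl chain, would give a step beyond the scatter.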